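Cyclohexyl for tert-butyl on a plasma-labile acyloxymethyl ester

This account rests on a few compounds, and the source may have more. Where it says the series, first, only, none or still open, it means among the compounds named here.

Measured compounds:
Compound 1 `C[C@@H](O)[C@H]1C(=O)N2C(C(=O)OCOC(=O)C(C)(C)C)=C(S[C@@H]3CN[C@H](C(=O)Nc4cccc(C(=O)OCOC(=O)C(C)(C)C)c4)C3)[C@H](C)[C@H]12` gives 2% in an ADME assay on a cell-free system (plasma, Rattus norvegicus) for metabolic stability, read by LC-MS, with a stated time of 60 min, at 37 degrees C, tested at 50 uM; a lower number here means that less of the compound is left, a higher number that more of the compound is left.
Compound 2 `C[C@@H](O)[C@H]1C(=O)N2C(C(=O)OCOC(=O)C(C)(C)C)=C(S[C@@H]3CN[C@H](C(=O)Nc4cccc(C(=O)O)c4)C3)[C@H](C)[C@H]12` gives 0% in this assay.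
Compound 3 `C[C@@H](O)[C@H]1C(=O)N2C3=C(S[C@@H]4CN[C@@H](C4)C(=O)Nc4cccc(c4)C(=O)OCc4oc(=O)oc4COC3=O)[C@H](C)[C@H]12` gives 0% in this assay.

Compound 2 sits level with compound 3 at the digits shown, the two together the lowest of the three numbers; compound 1 stands a number 2 percentage points lower from compound 1 to compound 2 (within the scatter), a step within the scatter. Compound 4 `C[C@@H](O)[C@H]1C(=O)N2C(C(=O)OCOC(=O)C3CCCCC3)=C(S[C@@H]3CN[C@H](C(=O)Nc4cccc(C(=O)O)c4)C3)[C@H](C)[C@H]12` differs from compound 2 by cyclohexyl in place of tert-butyl on a carbonyl carbon. Within the data shown here, no measured step touches this exchange: the one step known removes the whole (((tert-butyl)carbonyl)oxy)methyl group and moves nothing beyond the scatter. Compound 4 is therefore expected to show a number 1 percentage points higher from compound 2 to compound 4 (within the scatter), and its estimated value is 1%, with a range from 0% to 10%.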

Compound 4, percent of the compound remaining: 0%
Compound 4: middle estimate off by 1 percentage points, on the high side; the measured number falls inside the stated range.
By their numbers in this assay, from the lowest: compounds 2, 3, 4 and 1 (each within the scatter of the next).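

In this assay, cyclohexyl in place of tert-butyl on a carbonyl carbon gives no change at the digits printed from compound 2 to compound 4 (within the scatter). Among these compounds, this is the first measured exchange within the group itself, as the earlier step removed the whole (((tert-butyl)carbonyl)oxy)methyl group, and the added ring does not separate compound 4 from compound 2 in this read-out. Nothing available here accounts for this result. As far as these compounds go, whether an amine or a longer chain on this carbonyl carbon would leave more of the compound remaining stays open.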